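This account rests on a few compounds, and the source may have more. Where it says the series, first, only, none or still open, it means among the compounds named here.

Of the compounds shown here, two of a shared core have been tested in a functional assay on UACC-257 cells (Homo sapiens) for cytotoxicity, read by sulforhodamine B assay, with a stated time of 48 h, tested at 100 uM; a lower number here means a stronger effect, a higher number a weaker effect of the compound at the concentration tested. Compound 1 `COc1cc(-c2cc(/C=C/C(=O)c3ccc(N)cc3)[nH]n2)cc(OC)c1OC` carries a 4-aminophenyl on the carbonyl carbon; in this assay compound 1 gives -93%. Compound 2 `COc1ccc(C(=O)/C=C/c2cc(-c3cc(OC)c(OC)c(OC)c3)n[nH]2)cc1OC` carries a 3,4-dimethoxyphenyl in that place, and in this assay compound 2 gives -97%. Within the data shown here, compound 2 thus holds the lowest of the two numbers; its only neighbour is compound 1, with a number 4 percentage points lower from compound 1 to compound 2 (within the scatter), a step within the scatter.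

The step now followed leads from compound 2 to compound 3 `COc1cc(-c2cc(/C=C/C(=O)c3ccc(F)c(F)c3)[nH]n2)cc(OC)c1OC`, in which (3,4-difluorophenyl in place of 3,4-dimethoxyphenyl on a carbonyl carbon). Among the measured compounds shown here, only one measured step bears on this change: the exchange of the aryl group on the carbonyl carbon, from compound 1 to compound 2, moved this assay by a number 4 percentage points lower from compound 1 to compound 2 (within the scatter), that is, not beyond the scatter. Both measured compounds sit at a strong effect, so the expected change for compound 3 is again none beyond the scatter, a number 7 percentage points higher from compound 2 to compound 3 (within the scatter). In this assay compound 3 is therefore estimated at -90%, with a range from -100% to -70%.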

Compound 3, a percentage reported as activity, at one concentration (the size of the read-out at that concentration, not a potency): -37%
Compound 3: the middle estimate sits 53 percentage points below what was measured, outside the stated range (above it).
By their numbers in this assay, from the lowest: compounds 2 and 1 (each within the scatter of the next); then compound 3.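

In this assay, the aryl group on the carbonyl carbon now proves able to change the read-out: the earlier exchange at this place stayed within the scatter, whereas 3,4-difluorophenyl gives a number 60 percentage points higher from compound 2 to compound 3 (beyond the scatter) and, set against the 4-aminophenyl, a number 56 percentage points higher from compound 1 to compound 3 (beyond the scatter). The place is therefore not indifferent to what it carries, and of the three groups shown, only the 3,4-difluorophenyl stands apart, while the 3,4-dimethoxyphenyl and the 4-aminophenyl remain within the scatter of each other. The change swaps a group with 2 hydrogen-bond acceptors for one with 0, but nothing measured here explains the loss, and no supporting data bear on why this exchange weakens the effect.

The compounds shown leave open whether the drop belongs to fluorine itself or to the loss of the methoxy groups, which a plain phenyl, a 4-fluorophenyl or a 3,4-dichlorophenyl on the carbonyl carbon could help separate. They also leave open how far these compounds differ in potency, since each read-out comes from a single concentration.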